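A few compounds are considered here, and "the series" means these few. Any claim that something is new, unique, unknown or untested is made for them only; others in the source may bear on it.

Working notes on the series in a functional assay on a cell-free system (plasma, Homo sapiens) for inhibition, with Plasma (Rattus norvegicus) as the target; a lower number here means a stronger inhibitor, a higher number a weaker inhibitor. Compound 1 (`CCCCOc1ccc2c(N3CCNCC3)cc(=O)oc2c1C`) gives 5030 nM and compound 2 (`COCOc1ccc2c(N3CCNCC3)cc(=O)oc2c1C`) gives 3500 nM. Within the data shown here, compound 2 therefore stands within the scatter of compound 1, its only measured neighbour. The next compound is compound 3 (`CSCOc1ccc2c(N3CCNCC3)cc(=O)oc2c1C`), and the change is methylsulfanyl in place of methoxy on a saturated chain carbon bound to an oxygen on an aromatic ring. Among the measured compounds shown here, the one measured step that bears on this place is a 1.4-fold lower number from compound 1 to compound 2 (0.16 log units; within the scatter), and it stays within the scatter. For the measured compounds named here, no measured compound carries methylsulfanyl, so this rests on a single comparison. No step beyond the scatter is expected in this assay, in either direction. The expected step is a 1.1-fold higher number from compound 2 to compound 3 (0.04 log units; within the scatter). For compound 3 the estimated value is 3800 nM, with an expected range from 1700 nM to 8500 nM.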

Compound 3, half-maximal inhibitory concentration: 3400 nM
Compound 3: the middle estimate sits 1.1-fold (0.05 log units) above what was measured; the range from low to high includes it.
By their numbers in this assay, from the lowest: compounds 3, 2 and 1 (each within the scatter of the next).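

In this assay, methylsulfanyl in place of methoxy gives a 1.0-fold lower number from compound 2 to compound 3 (0.01 log units; within the scatter), so exchanging oxygen for sulfur on a saturated chain carbon bound to an oxygen on an aromatic ring produces no step beyond the scatter. Methylsulfanyl in place of propyl gives a 1.5-fold lower number from compound 1 to compound 3 (0.17 log units; within the scatter), which also stays within the scatter, so all three groups shown at this place read alike and the flat result is no longer a single comparison. Nothing on hand accounts for this flat reading.

From the compounds shown here alone, whether any group at this place can move the number beyond the scatter remains open, and an amine, a carboxylic acid or a longer chain would test that. The shared core is the same in all three compounds, so they say nothing about changes elsewhere on it.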